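Ring-methyl epimer: expected activity of compound 3

The compounds below may be only part of what the source reports. "The series", "measured", "known", "first", "only" and "open" are said of these compounds alone.

Measured so far:
compound 1, `C=C1C(=O)O[C@H]2CCCCC[C@@H]12`: 76%
compound 2, `C=C1C(=O)O[C@H]2CC[C@H](C)CC[C@@H]12`: 50%
compound 3, `C=C1C(=O)O[C@H]2CC[C@@H](C)CC[C@@H]12`: not yet measured

In a functional assay on P388 cells (Mus musculus) for inhibition, with a stated time of 48 h, tested at 1 ug/mL (a higher number here means a stronger effect of the compound at the concentration tested, a lower number a weaker effect), compound 1 gives 76%, while compound 2 gives 50%. Among the compounds with values here, compound 2 therefore stands lowest of the two numbers, its only neighbour being compound 1. Within the data shown here, the single measured step, a number 26 percentage points lower from compound 1 to compound 2 (beyond the scatter), is the placing of a methyl on a saturated ring carbon, and it was beyond the scatter.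

Compound 3 differs from compound 2 as follows: the two compounds have the same atoms and bonds and differ only in configuration as drawn: 1 of 3 stereo elements differ; a stereocentre at a saturated ring carbon is drawn R in compound 2 and S in compound 3. Among the measured compounds shown here, no measured step concerns a change of configuration alone; the step for methyl introduction bears on this only insofar as compound 2 already carries the methyl. With nothing to point either way, the step is expected to stay within the scatter, giving an estimated no change at the digits printed from compound 2 to compound 3 (within the scatter). Compound 3 is estimated at 50%, with a range of 30% to 72%.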

Compound 3, a percentage reported as activity, at one concentration (the size of the read-out at that concentration, not a potency): 69%
Compound 3: the middle estimate sits 19 percentage points below what was measured; the range from low to high includes it.
By their numbers in this assay, from the lowest: compound 2; then compounds 3 and 1 (each within the scatter of the next).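

In this assay, within the data shown here, inverting the drawn configuration at this saturated ring carbon gives a number 19 percentage points higher from compound 2 to compound 3 (beyond the scatter), so the orientation of the methyl matters here, which the earlier compounds could not show. This step can be assigned to configuration alone: the fact that compounds 2 and 3 differ only in the configuration as drawn. The earlier drop therefore does not apply to the methyl as such, since the methyl step in the other configuration reads a number 7 percentage points lower from compound 1 to compound 3 (within the scatter), leaving compound 3 and compound 1 indistinguishable in this read-out.

From the compounds shown here alone, whether an ethyl or a hydroxyl group at the same carbon would show the same dependence on configuration remains open. Also open, going by these compounds, is whether the gap between the two methyl epimers would persist at other concentrations.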